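This account rests on a few compounds, and the source may have more. Where it says the series, first, only, none or still open, it means among the compounds named here.

Compound 1, `CCOC(=O)C1=C(Nc2ccccc2)S/C(=C\c2ccc(O)c(O)c2)C1=O`: in a functional assay on A549 cells (Homo sapiens) for inhibition, read by MTT assay, with a stated time of 72 h, tested at 10 uM (a lower number here means less inhibition, a higher number more inhibition at the concentration tested (going by the name of the read-out)), compound 1 gives 30.7%.
Compound 2, `CCOC(=O)C1=C(Nc2ccccc2)S/C(=C\c2cccc(C(=O)O)c2)C1=O`: in this assay compound 2 reaches only the limit of the assay, < 10%, and not a number.
Compound 3, `CCOC(=O)C1=C(Nc2ccc(OC)cc2)S/C(=C\c2ccc[nH]2)C1=O`: in this assay compound 3 likewise stops at the limit of the assay, < 10%, so no number is known for it.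

Compound 3 therefore stands at the bottom of what this assay can report, and it is not alone there, since (the limit of < 10% in this assay, at which 2 of the 3 values shown sit). Going by the values given here, the single measured step, a number at least 20.7 percentage points lower from compound 1 to compound 2 (beyond the scatter), changes the group on the double-bonded chain carbon; the aniline ring, on which the present change falls, is untouched in that step, so it gives no direct guidance here.

The change to compound 4, `CCOC(=O)C1=C(Nc2ccc(F)cc2)S/C(=C\c2ccc[nH]2)C1=O`, is fluoro in place of methoxy on an aromatic carbon. Among the compounds with values here, no measured pair shows what fluoro in place of methoxy does to this read-out, so the expectation rests on compound 3 sitting at the limit and on the small size of the swap. The expected step is a step that the limit leaves unreadable from compound 3 to compound 4, that is, none beyond the scatter. Compound 4 is therefore estimated at 8%, with a range from 0% to 22%, most likely again only a limit.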

Compound 4, a percentage reported as inhibition, at one concentration (the size of the read-out at that concentration, not a potency): < 10%
Compound 4 gave a limit, no number; the forecaster's own chance of this, stated with the estimate: 70%; the middle value lies beyond the limit too.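

In this assay compound 4 gives < 10% as a limit of the assay and not a number. Compound 3 also sits at a limit, so no step can be read between compound 3 and compound 4: (the limit of < 10% in this assay, at which 3 of the 4 values shown sit). The compounds shown leave open whether 4-fluorophenyl in place of 4-methoxyphenyl changes the inhibition at all.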